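The compounds below may be only part of what the source reports. "The series", "measured", "known", "first", "only" and "open" are said of these compounds alone.

This set of two measured compounds and one still to be tested shares one core, and the work turns on how a small change on a sulfonyl group may shift the rate at which liver enzymes break the molecule down. In an ADME assay on microsomes from liver (Homo sapiens) for metabolic stability, tested at 2.5 uM (on this read-out lower numbers stand for slow clearance and higher numbers for fast clearance), compound 1 `COc1ccc(-c2c(S(=O)(=O)c3ccc(F)cc3)cnc3c(F)cccc23)cc1` gives 2.41 mL/min. Compound 2 `COc1cccc(-c2c(S(=O)(=O)c3cccc(F)c3)cnc3c(F)cccc23)c1`, which also carries a fluorine on the ring attached to the sulfonyl sulfur, gives 2.6 mL/min in this assay; this lies within the usual scatter of the result for compound 1, so the two cannot be told apart. Compound 3 `COc1cccc(-c2c(S(=O)(=O)c3ccc(F)cc3)cnc3c(F)cccc23)c1` differs from compound 2 in one place only: 4-fluorophenyl in place of 3-fluorophenyl on a sulfonyl sulfur. Within the data shown here, no measured pair shows what such a change does, and the two known values offer no lead. The step of a 1.0-fold lower number from compound 2 to compound 3 (0.02 log units; within the scatter) is expected to be small, with no direction beyond the scatter. Compound 3 is expected to give 2.5 mL/min, within a likely range from 1.6 mL/min to 3.9 mL/min.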

Compound 3, intrinsic clearance in a liver preparation (reported as CLH), per the amount of preparation that the assay uses: 2.23 mL/min
Beside the measured number, compound 3's estimate is 1.1-fold (0.05 log units) above it, and the stated range covers the measured number.
By their numbers in this assay, from the lowest: compounds 3, 1 and 2 (each within the scatter of the next).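

With the rest of the molecule held fixed, 4-fluorophenyl in place of 3-fluorophenyl on a sulfonyl sulfur gives a 1.2-fold lower number from compound 2 to compound 3 (0.07 log units; within the scatter) in this assay, so this position now has a measured pair, and the two fluorine placements cannot be told apart. The result also supplies a second single-change pair, because 3-methoxyphenyl in place of 4-methoxyphenyl on an aromatic carbon gives a 1.1-fold lower number from compound 1 to compound 3 (0.03 log units; within the scatter), and these two compounds cannot be told apart either. Nothing available explains how the molecule is broken down in this preparation or where that happens.

On these data alone, both pairs exchange only one placement of the same group for another, so the effect of a different group, such as an amine or a carboxylic acid, on the ring attached to the sulfonyl sulfur remains open. As far as these compounds go, it is also open whether the fluorine swap would give a similar result with 4-methoxyphenyl on the core.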